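Swapping the five-membered ring for a pyridine

The source may report more compounds than this note shows. Statements on the series, on what has been measured and on what is new or still open speak of the compounds shown alone.

Measured compounds:
- compound 1 `CNC(=O)N1CCCc2ccc(NC(=O)c3ccc(-c4cc[nH]n4)cc3)cc21`: 92.5%
- compound 2 `CNC(=O)N1CCCc2ccc(NC(=O)c3cccc(-c4ccn(S(C)(=O)=O)n4)c3)cc21`: 4.03%
- compound 3 `CNC(=O)N1CCCc2ccc(NC(=O)c3cccc(-c4ccn(C(C)=O)n4)c3)cc21`: 27.6%

All three share one core and were tested in a functional assay on MV4-11 cells (Homo sapiens) for antiproliferative activity, with a stated time of 6 days, tested at 1.56 uM; on this read-out lower numbers stand for a weaker effect and higher numbers for a stronger effect at the one concentration tested. Compound 1 stands highest of the three numbers; compound 3 lies far beneath it, and compound 2 lies furthest beneath. Among the compounds with values here, the only step between measured compounds that differ in one place is a number 23.6 percentage points higher from compound 2 to compound 3 (beyond the scatter), an acetyl in place of methylsulfonyl on an aromatic nitrogen, which says nothing directly about the ring itself.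

Compound 4 `CNC(=O)N1CCCc2ccc(NC(=O)c3ccc(-c4cccnc4)cc3)cc21` is not yet measured. It differs from compound 1 in one place: pyridin-3-yl in place of 1H-pyrazol-3-yl on an aromatic carbon. The hydrogen-bond donor of the five-membered ring is thereby lost. Within the data shown here, no measured step covers this exchange, so the expectation rests only on what compound 2 and compound 3 show: both carry a five-membered ring without that donor, and both give much lower numbers than compound 1, although they also differ from compound 1 in where the ring sits. A sizeable drop in this assay is therefore expected for compound 4, by a number 47.5 percentage points lower from compound 1 to compound 4 (beyond the scatter), but with wide uncertainty. Compound 4 is estimated at 45%, within 10% to 85%.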

Compound 4, a percentage reported as inhibition, at one concentration (the size of the read-out at that concentration, not a potency): 62.5%
The estimate for compound 4 lay 17.5 percentage points below the measured number, within the range that was stated.
By their numbers in this assay, from the lowest: compound 2; then compound 3; then compound 4; then compound 1.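

In this assay, within the data shown here, this is the first direct reading of a ring exchange at this place on the aromatic carbon, para to a large group, and it gives a number 30 percentage points lower from compound 1 to compound 4 (beyond the scatter). Because the step is beyond the usual scatter, the choice of ring here clearly matters, yet the change does not remove the effect: compound 4, whose pyridin-3-yl has 0 hydrogen-bond donors where 1H-pyrazol-3-yl has 1, still gives 62.5% in this assay, so a hydrogen-bond donor on this ring is not needed for a sizeable read-out at the one concentration tested, although ring size and the number of hetero atoms change in the same exchange and cannot be separated from the donor. Nothing available explains the size of this step.

The compounds shown leave open which of these differences accounts for the step, a question that a plain phenyl ring, a pyridin-4-yl or a 1H-imidazol-4-yl at the same place could help to address. They also leave open how compound 1 and compound 4 compare in potency, since a single concentration gives the size of the read-out and not a potency.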